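Switching the aryl group of a chalcone

The source may hold more compounds than are shown below. What is called first, only, known or untested is meant among the compounds shown, and "the series" means these compounds.

The series is followed in a functional assay on CAL-51 cells (Homo sapiens) for inhibition, read by sulforhodamine B assay, with a stated time of 3 days; a lower number here means a stronger inhibitor of growth, a higher number a weaker inhibitor of growth. Going by the values given here, compound 1 `O=C(/C=C/c1ccccc1Cl)c1ccc(OCc2ccccc2)cc1` gives 7100 nM, the higher of the two numbers measured so far. Compound 2 `O=C(/C=C/c1cccc([N+](=O)[O-])c1)c1ccccc1` gives 1080 nM, a lower number by a gap that exceeds the scatter. The next candidate, compound 3 `COc1cccc(/C=C/C(=O)c2ccc(OCc3ccccc3)cc2)c1`, differs from compound 1 in a single place: 3-methoxyphenyl in place of 2-chlorophenyl on a double-bonded chain carbon bound to a double-bonded chain carbon. Among the compounds with values here, no measured pair shows this change directly, so the expected step is only a 1.4-fold lower number from compound 1 to compound 3 (0.15 log units; within the scatter). For compound 3 the expected value is 5000 nM, within 1500 nM to 15000 nM.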

Compound 3, concentration for 50% growth inhibition: 13700 nM
Estimate against measurement, compound 3: 2.7-fold (0.44 log units) below; measured number inside the range.
By their numbers in this assay, from the lowest: compound 2; then compounds 1 and 3 (each within the scatter of the next).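

In this assay, placing 3-methoxyphenyl in place of 2-chlorophenyl on a double-bonded chain carbon bound to a double-bonded chain carbon gives a 1.9-fold higher number from compound 1 to compound 3 (0.29 log units; within the scatter). Going by these compounds alone, this is the first direct reading at this position, and the two aryl groups cannot be told apart here, even though the entering group carries one hydrogen-bond acceptor and the leaving group none. No supporting evidence bears on this result. From the compounds shown here alone, whether an amine or a carboxylic acid on this aryl ring would move the number beyond the scatter remains open.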